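The source may report more compounds than this note shows. Statements on the series, on what has been measured and on what is new or still open speak of the compounds shown alone.

Measured compounds in an assay on T-REx-293 cells for inhibition of potassium channel subfamily T member 1 (Homo sapiens), read by patch clamp; a higher number here means a weaker inhibitor, a lower number a stronger inhibitor:
- compound 1, `C[C@H](NC(=O)c1cc(C(F)(F)F)nn1C)c1nc(-c2cccc(F)c2)no1`: 136 nM
- compound 2, `Cc1ccnc(-c2noc([C@H](C)NC(=O)c3cc(C(F)(F)F)nn3C)n2)c1`: 4470 nM
- compound 3, `C[C@H](NC(=O)c1cc(C(F)(F)F)nn1C)c1nc(-c2ccnc(C(F)F)c2)no1`: 61 nM

Compound 3 carries the lowest number of the three. It sits a 2.2-fold lower number from compound 1 to compound 3 (0.35 log units; beyond the scatter) and a 73-fold lower number from compound 2 to compound 3 (1.86 log units; beyond the scatter), both beyond the scatter, so it is the strongest inhibitor of the measured set.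

Compound 4, `C[C@H](NC(=O)c1cc(C(F)(F)F)nn1C)c1nc(-c2ccnc(C(F)(F)F)c2)no1`, differs from compound 3 by fluoro in place of hydrogen on a saturated chain carbon bound to an aromatic carbon and two fluorine atoms. Among the measured compounds shown here, no measured step covers this change: the measured steps all swap the whole aryl group on the shared core, and the one that bears most on it, a 2.2-fold lower number from compound 1 to compound 3 (0.35 log units; beyond the scatter), is only modest, while a 33-fold higher number from compound 1 to compound 2 (1.52 log units; beyond the scatter) is large for a different aryl. A change of a single fluorine on a side chain is far smaller than any of these, so the expectation for compound 4 in this assay is a step of a 1.1-fold lower number from compound 3 to compound 4 (0.04 log units; within the scatter), that is, no shift beyond the scatter in either direction.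

Compound 4 is therefore estimated at 55 nM, with a range from 20 nM to 150 nM.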

Compound 4, half-maximal inhibitory concentration: 40 nM
Estimate against measurement, compound 4: 1.4-fold (0.14 log units) above, within the range that was stated.
By their numbers in this assay, from the lowest: compounds 4 and 3 (each within the scatter of the next); then compound 1; then compound 2.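

In this assay, among the compounds shown here, difluoromethyl to trifluoromethyl is the first change confined to a single fluorine, and a 1.5-fold lower number from compound 3 to compound 4 (0.18 log units; within the scatter) leaves the two compounds within the scatter of each other, so this carbon accepts the third fluorine without a readable shift. The advantage of this aryl position over the other groups also holds with trifluoromethyl: 2-(trifluoromethyl)pyridin-4-yl gives a 3.4-fold lower number from compound 1 to compound 4 (0.53 log units; beyond the scatter) against 3-fluorophenyl and a 110-fold lower number from compound 2 to compound 4 (2.05 log units; beyond the scatter) against 4-methylpyridin-2-yl. Nothing available here accounts for these steps.

Open, from the compounds shown here alone, is whether fluorine matters at all on this carbon: a plain methyl, a nitrile or a methoxy on the pyridin-4-yl group would test that. Compound 2 differs from compound 4 in both the substituent and the pyridine attachment, so the two contributions remain unseparated.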